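The compounds below may be only part of what the source reports. "The series", "measured", "known", "first", "only" and "open" are said of these compounds alone.

Measured so far in a functional assay on MCF7 cells (Homo sapiens) for cytotoxicity, read by MTT assay, with a stated time of 96 h; on this read-out higher numbers stand for weaker inhibition and lower numbers for stronger inhibition:
compound 1 `COc1cccc(-n2cc(C(=O)c3cc(OC)c(OC)c(OC)c3)c(-c3ccccc3)c2)c1` gives 500 nM
compound 2 `COc1cc(C(=O)c2cn(-c3ccc(Br)cc3)cc2-c2ccccc2)cc(OC)c1OC` gives 20 nM
compound 3 `COc1cc(C(=O)c2cn(-c3ccccc3)cc2-c2ccccc2Br)cc(OC)c1OC` gives 190 nM

Among these three, compound 3 takes the middle place, with a lower number than compound 1 and a higher number than compound 2. Both gaps lie beyond the usual scatter. Next comes compound 4 `COc1ccccc1-c1cn(-c2ccccc2)cc1C(=O)c1cc(OC)c(OC)c(OC)c1`, which differs from compound 3 by a single swap (methoxy in place of bromo on an aromatic carbon). Methoxy takes the place of bromo on an aromatic carbon, ortho to a large group.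

Among the measured compounds shown here, only one measured step bears on this, and only loosely. It is a 25-fold lower number from compound 1 to compound 2 (1.40 log units; beyond the scatter) in this assay and came when a ring carrying bromo replaced a ring carrying methoxy on an aromatic nitrogen. The swap now in question runs the other way and at a different place, so a smaller rise is expected, though the data cannot confirm it. The expected step is a 1.8-fold higher number from compound 3 to compound 4 (0.27 log units; within the scatter) toward weaker inhibition. For compound 4 the estimated value is 350 nM with an expected range from 90 nM to 1300 nM as the upper end.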

Compound 4, half-maximal inhibitory concentration: 190 nM
Estimate against measurement, compound 4: 1.8-fold (0.27 log units) above; the measured number falls inside the stated range.
By their numbers in this assay, from the lowest: compound 2; then compounds 3 and 4 (each within the scatter of the next); then compound 1.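

Putting methoxy in place of bromo on this aromatic carbon, ortho to a large group, gives no change at the digits printed from compound 3 to compound 4 (within the scatter) in this assay. At this place, then, the two groups cannot be told apart in this assay, although methoxy carries a hydrogen-bond acceptor and bromo does not, whereas the earlier swap on the aromatic nitrogen gave a 25-fold lower number from compound 1 to compound 2 (1.40 log units; beyond the scatter) and so showed a large step. Nothing measured here explains why 2-bromophenyl and 2-methoxyphenyl read alike.

From the compounds shown here alone, it remains open whether this place would accept a very different group just as readily, such as an amine, a carboxylic acid or a longer chain. Going by these compounds, it is also open whether bromo and methoxy would still read alike here with the 4-bromophenyl of compound 2 on the aromatic nitrogen.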